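A few compounds are considered here, and "the series" means these few. Any claim that something is new, unique, unknown or untested is made for them only; others in the source may bear on it.

Measured compounds:
compound 1 `COc1cc(OC)cc(N2NC3=CC[C@@H](OC)O[C@@]3(c3ccccc3)CC2=O)c1`: 19500 nM
compound 2 `COc1cc(OC)cc(N2NC3=CC[C@@H](OC)O[C@@]3(C)CC2=O)c1`: 23700 nM
compound 3 `CO[C@@H]1CC=C2NN(c3cncnc3)C(=O)C[C@]2(C)O1`: 16600 nM

In a functional assay on SK-N-SH cells (Homo sapiens) for inhibition, read by sulforhodamine B assay, with a stated time of 48 h (on this read-out higher numbers stand for weaker inhibition and lower numbers for stronger inhibition), compound 2 gives 23700 nM and compound 1 gives 19500 nM; the step of a 1.2-fold lower number from compound 2 to compound 1 (0.08 log units; within the scatter) is phenyl in place of methyl on a saturated ring carbon. Compound 3, with a different core, gives 16600 nM in this assay; how the core of compound 3 differs from that of compound 2 is not broken down here. Compound 4 `CO[C@@H]1CC=C2NN(c3cncnc3)C(=O)C[C@]2(c2ccccc2)O1` has not yet been measured. It differs from compound 3 by phenyl in place of methyl on a saturated ring carbon. This is the same kind of change as that from compound 2 to compound 1, but the place differs: in compound 4 the saturated ring carbon lies in a six-membered non-aromatic ring with one oxygen, next to the ring oxygen, whereas in compound 1 it lies in a ring with two nitrogen. Because a 1.2-fold lower number from compound 2 to compound 1 (0.08 log units; within the scatter) was within the scatter, the expected step of a 1.2-fold lower number from compound 3 to compound 4 (0.07 log units; within the scatter) is small, and compound 4 is estimated at 14000 nM, between 6000 nM and 32000 nM.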

Compound 4, half-maximal inhibitory concentration: 8200 nM
The estimate for compound 4 lay 1.7-fold (0.23 log units) above the measured number; low and high end bracket the measured number.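

In this assay, phenyl in place of methyl on a saturated ring carbon gives a 2.0-fold lower number from compound 3 to compound 4 (0.31 log units; beyond the scatter), a modest step. Set beside the earlier step on the other core, the two do not differ by more than the scatter, so the change carries across these two cores without a measurable difference: the same change on two cores in this assay, a 1.2-fold lower number (0.08 log units; within the scatter) from compound 2 to compound 1 and a 2.0-fold lower number (0.31 log units; beyond the scatter) from compound 3 to compound 4, 1.7-fold (0.22 log units) apart, within the scatter of two such steps. For the compounds shown here, this does not show that the change acts identically on both cores or that it would carry to a further core, since it rests on only two pairs and only the step on the core of compound 3 lies beyond the scatter.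

The compounds shown leave open how an amine or a longer chain would read at this saturated ring carbon. They also leave open what a hydroxyl group would give in place of the methoxy group.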